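The compounds below may be only part of what the source reports. "The series", "measured", "known", "first", "only" and "open" are said of these compounds alone.

Three compounds have been measured in an ADME assay on L6 cells (Rattus norvegicus) for cytotoxicity, read by resazurin assay, with a stated time of 70 h; a lower number here means a stronger inhibitor, a higher number a weaker inhibitor:

compound 1, `c1ccc(OCCCOc2cccc(-c3cc4ccc(C5=NCCN5)cc4o3)c2)cc1`, giving 10100 nM
compound 2, `c1ccc(OCCCCOc2cccc(-c3cc4ccc(C5=NCCN5)cc4o3)c2)cc1`, giving 5800 nM
compound 3, `N=C(N)c1ccc2cc(-c3ccc(OCCCCOc4ccccc4)cc3)oc2c1`, giving 14100 nM

Compound 1 and compound 2 share a core and differ in one place: phenoxymethyl in place of phenoxy on a saturated chain carbon, three bonds along the chain from an oxygen on an aromatic ring. In this assay this change gave a 1.7-fold lower number from compound 1 to compound 2 (0.24 log units; within the scatter), a step that stays within the ordinary spread of repeated measurements, so the two numbers cannot be told apart with confidence.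

Compound 3 carries a different core; the difference between the two cores is not broken down here. Its value in this assay sits close to that of compound 1, while compound 2 gives a number that lies beyond the usual spread from compound 3.

Compound 4, `N=C(N)c1ccc2cc(-c3ccc(OCCCCCOc4ccccc4)cc3)oc2c1`, has not yet been measured. It differs from compound 3 in one place: phenoxymethyl in place of phenoxy on a saturated chain carbon, four bonds along the chain from an oxygen on an aromatic ring. Among the measured compounds shown here, this is the same kind of change as the one from compound 1 to compound 2, though not the same: in compound 1 the change sits on a saturated chain carbon three bonds along the chain from an oxygen on an aromatic ring, whereas in compound 3 it sits four bonds along the chain from such an oxygen. For the measured compounds named here, only one measured pair shows this change, and on another core, so the guide is loose.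

Compound 4 is expected to give 9500 nM in this assay, with a likely range from 4500 nM to 20000 nM. For compound 4 this means an expected step of a 1.5-fold lower number from compound 3 to compound 4 (0.17 log units; within the scatter). That expectation rests on the small measured a 1.7-fold lower number from compound 1 to compound 2 (0.24 log units; within the scatter) and on compound 3 giving 14100 nM as the starting point.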

Compound 4, half-maximal inhibitory concentration: 9000 nM
For compound 4 the middle estimate is 1.1-fold (0.02 log units) above the measured one; measured number inside the range.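

In this assay, putting phenoxymethyl in place of phenoxy on the saturated chain carbon gave a 1.6-fold lower number from compound 3 to compound 4 (0.19 log units; within the scatter), so the two numbers cannot be told apart with confidence. Set beside the earlier step on the other core, the new step looks much the same, and the two steps cannot be separated: the same change on two cores in this assay, a 1.7-fold lower number (0.24 log units; within the scatter) from compound 1 to compound 2 and a 1.6-fold lower number (0.19 log units; within the scatter) from compound 3 to compound 4, 1.1-fold (0.05 log units) apart, within the scatter of two such steps

This shows that, on these two cores, the change gave steps of similar size and direction, and neither step moved the number beyond the ordinary spread of repeated measurements. Among the compounds shown here, it does not show that the change has a real effect of its own: each step could be scatter alone, the agreement rests on only two pairs, and neither pair says how the change would behave on a third core.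

The compounds shown leave open whether a longer chain, such as one ending in 3-phenoxypropyl, would move the number beyond the scatter on either core. They also leave open what would happen with an amine or a carboxylic acid in place of phenoxy at the end of the chain.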